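Swapping the Piperidine Amide for a Trimethoxyphenyl

This account rests on a few compounds, and the source may have more. Where it says the series, first, only, none or still open, it means among the compounds named here.

Going by the values given here, compound 2 `COc1cc(-c2nc3cc(/C=C4\SC(=O)N(CC(=O)N5CCCCC5)C4=O)ccc3[nH]2)cc(OC)c1OC` is the only member of this set with a number in an ADME assay on HEK-293T cells (Homo sapiens) for inhibition, read by MTT assay, with a stated time of 48 h; on this read-out higher numbers stand for weaker inhibition and lower numbers for stronger inhibition: compound 2 gives 21500 nM. Compound 1 `COc1ccc(-c2nc3cc(/C=C4\SC(=O)N(CC(=O)N5CCOCC5)C4=O)ccc3[nH]2)cc1OC` reaches only the limit > 50000 nM. Compound 3 `COc1cc(OC)c(-c2nc3cc(/C=C4\SC(=O)N(CC(=O)N5CCCCC5)C4=O)ccc3[nH]2)cc1OC` likewise stops at the limit > 50000 nM. Among the compounds with values here, the single measured step, an at least 2.3-fold higher number from compound 2 to compound 3 (0.36 log units; beyond the scatter), is bounded because of the limit of > 50000 nM in this assay, at which 2 of the 3 values shown sit. Compound 4 `COc1cc(CN2C(=O)S/C(=C\c3ccc4[nH]c(-c5cc(OC)c(OC)c(OC)c5)nc4c3)C2=O)cc(OC)c1OC` differs from compound 2 by 3,4,5-trimethoxyphenyl in place of (piperidin-1-yl)carbonyl on a saturated chain carbon bound to an amide-type nitrogen in a ring. Within the data shown here, no measured step touches that position, so the numbers give no direction for this change; with two of three values at the limit, weak inhibition is expected to persist, and the expected step is a 1.4-fold higher number from compound 2 to compound 4 (0.14 log units; within the scatter), not beyond the scatter. Compound 4 is estimated at 30000 nM in this assay, between 10000 nM and 90000 nM.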

Compound 4, half-maximal inhibitory concentration: 16600 nM
Estimate against measurement, compound 4: 1.8-fold (0.26 log units) above, within the range that was stated.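

In this assay, the position on a saturated chain carbon bound to an amide-type nitrogen in a ring now has its first measured step: a 1.3-fold lower number from compound 2 to compound 4 (0.11 log units; within the scatter). The two values lie within the scatter of each other, so a measurable number here does not depend on the (piperidin-1-yl)carbonyl group, and 3,4,5-trimethoxyphenyl serves equally well in compound 4. As far as these compounds go, whether an amine or a carboxylic acid at this position would give a clearly different number stays open. Any step towards weaker inhibition could be read only as a bound: the limit of > 50000 nM in this assay, at which 2 of the 4 values shown sit.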